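The source may report more compounds than this note shows. Statements on the series, on what has been measured and on what is new or still open speak of the compounds shown alone.

Measured in a functional assay on trachea (Cavia porcellus) for inhibition; on this read-out higher numbers stand for weaker inhibition and lower numbers for stronger inhibition:
Compound 1 `CCOC(=O)C1=C(C)NC(C)=C(C(=O)OCC)C1c1c(C(F)(F)F)nc2sccn12`: 1110 nM
Compound 2 `COC(=O)C1=C(C)NC(C)=C(C(=O)OC)C1c1c(-c2ccc(C(F)(F)F)cc2)nc2sccn12`: 61 nM

Compound 1 has the higher number of the two, and the gap to compound 2 lies beyond the scatter. The step to follow leads to compound 3 `CCOC(=O)C1=C(C)NC(C)=C(C(=O)OCC)C1c1c(-c2ccc(C(F)(F)F)cc2)nc2sccn12`: 4-(trifluoromethyl)phenyl in place of trifluoromethyl on an aromatic carbon, with 4-(trifluoromethyl)phenyl in place of trifluoromethyl on an aromatic carbon. Compound 2 also carries 4-(trifluoromethyl)phenyl and gives 61 nM, so a clearly lower number is expected in this assay. The estimated step is a 14-fold lower number from compound 1 to compound 3 (1.14 log units; beyond the scatter), expected to lie beyond the scatter. For compound 3 the expected value is 80 nM, with an estimated range of 25 nM to 250 nM.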

Compound 3, half-maximal inhibitory concentration: 130 nM
Beside the measured number, compound 3's estimate is 1.6-fold (0.21 log units) below it; low and high end bracket the measured number.
By their numbers in this assay, from the lowest: compound 2; then compound 3; then compound 1.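

In this assay, with the ester groups held constant, 4-(trifluoromethyl)phenyl in place of trifluoromethyl on this aromatic carbon gives an 8.5-fold lower number from compound 1 to compound 3 (0.93 log units; beyond the scatter). Compound 1 and compound 2 differ in more than one place, so this single change could only be read once compound 3 was available. Nothing measured here gives a cause for this step.

From the compounds shown here alone, it remains open whether the added aromatic ring alone carries the step, or whether its trifluoromethyl is also needed. Unsubstituted phenyl, 4-chlorophenyl or a methyl group at this carbon would address this.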